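Carbamate series at lysophosphatidic acid receptor 3: acid extension

The source may report more compounds than this note shows. Statements on the series, on what has been measured and on what is new or still open speak of the compounds shown alone.

Working notes on a set of carbamates sharing one core. Compound 1 `COc1ccc(-c2cnn(C)c2NC(=O)O[C@H](C)c2ccccc2)cc1` is tested in an in vitro functional assay on chem-1 cells for antagonist activity at lysophosphatidic acid receptor 3 (Homo sapiens), read by FLIPR and calcium flux, with stated times of 30 min and 100 s; a higher number here means a weaker inhibitor, a lower number a stronger inhibitor. In this assay compound 1 gives only a limit, > 30000 nM. Compound 2 `C[C@@H](OC(=O)Nc1c(-c2ccccc2F)cnn1C)c1ccccc1Cl` gives a limit as well, > 30000 nM. Compound 3 `C[C@H](OC(=O)Nc1c(-c2ccccc2F)cnn1C)c1ccccc1Cl` likewise gives a limit, > 30000 nM. The step that the two limits leave unreadable from compound 2 to compound 3 is unreadable because of the limit of > 30000 nM in this assay, at which 3 of the 3 values shown sit; it rests on the fact that compounds 2 and 3 differ only in the configuration as drawn and does not bear on a change of the aryl substituent. Compound 4 `C[C@@H](OC(=O)Nc1c(-c2ccc(-c3ccc(CC(=O)O)cc3)cc2)cnn1C)c1ccccc1` arises from compound 1 by 4-(carboxymethyl)phenyl in place of methoxy on an aromatic carbon. Going by the values given here, no measured step covers this change, so the expectation starts from the limit of compound 1 alone. Compound 4 is expected near 5000 nM in this assay, within 500 nM to 30000 nM. The estimated step of an at least 6.0-fold lower number from compound 1 to compound 4 (0.77 log units; beyond the scatter) is read against a limit.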

Compound 4, half-maximal inhibitory concentration: > 30000 nM
Compound 4: only a limit was reported (the forecaster's own chance of this, stated with the estimate: 40%); middle value at least 6.0-fold (0.77 log units) from the limit.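

No step from compound 1 to compound 4 can be read in this assay because both give only a limit: the limit of > 30000 nM in this assay, at which 4 of the 4 values shown sit.

The compounds shown leave open what effect 4-(carboxymethyl)phenyl in place of methoxy has on inhibition, since none gives a number.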